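A few compounds are considered here, and "the series" means these few. Any claim that something is new, unique, unknown or untested is made for them only; others in the source may bear on it.

For the measured compounds named here, in a functional assay on M21 cells (Homo sapiens) for antiproliferative activity, read by sulforhodamine B assay, with a stated time of 48 h (on this read-out lower numbers stand for stronger inhibition and higher numbers for weaker inhibition), three compounds sharing one core have numbers so far. Compound 1 (`CCc1ccccc1NS(=O)(=O)c1ccc(N2CCNC2=O)cc1`) gives 180 nM, compound 2 (`Cc1ccc(NS(=O)(=O)c2ccc(N3CCNC3=O)cc2)cc1`) gives 260 nM, and compound 3 (`O=C1NCCN1c1ccc(S(=O)(=O)Nc2ccccc2)cc1`) gives 200 nM. Compound 3 therefore stands within the scatter of both of the others, and the three values cannot be ranked. Compound 4 (`CCc1cccc(NS(=O)(=O)c2ccc(N3CCNC3=O)cc2)c1`) has not yet been measured. It differs from compound 3 by ethyl in place of hydrogen on an aromatic carbon, meta to a large group: ethyl in place of hydrogen on an aromatic carbon.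

Compound 1 also carries an ethyl on that ring, and the step that replaces it with hydrogen is the closest guide: a 1.1-fold higher number from compound 1 to compound 3 (0.05 log units; within the scatter). Replacing the methyl of compound 2 with hydrogen gives a similar picture: a 1.3-fold lower number from compound 2 to compound 3 (0.11 log units; within the scatter). The remaining step, a 1.4-fold higher number from compound 1 to compound 2 (0.16 log units; within the scatter), also stays small. Going by the values given here, no measured compound carries the ethyl exactly where compound 4 has it, so the evidence is indirect. Even so, none of the three steps leaves the scatter, and no step beyond the scatter is expected in this assay. The expected step is no change at the digits printed from compound 3 to compound 4 (within the scatter). For compound 4 the estimated value is 200 nM, with an expected range from 100 nM to 420 nM.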

Compound 4, half-maximal inhibitory concentration: 82 nM
Compound 4: the middle estimate sits 2.4-fold (0.39 log units) above what was measured; measured number below the stated range.
By their numbers in this assay, from the lowest: compound 4; then compounds 1, 3 and 2 (each within the scatter of the next).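

In this assay, for the compounds shown here, ethyl in place of hydrogen on an aromatic carbon, meta to a large group, produces the first change to leave the scatter, with a 2.4-fold lower number from compound 3 to compound 4 (0.39 log units; beyond the scatter), a modest step. Where the group sits on the ring now appears to matter: 3-ethylphenyl gives a 2.2-fold lower number from compound 1 to compound 4 (0.34 log units; beyond the scatter) when set against 2-ethylphenyl, and a 3.2-fold lower number from compound 2 to compound 4 (0.50 log units; beyond the scatter) when set against 4-methylphenyl, although the ethyl of compound 1 and the methyl of compound 2 had both stayed within the scatter of the plain phenyl of compound 3. Nothing available accounts for why this one placement of ethyl lowers the number.

The compounds shown leave open whether a methyl, a longer chain such as propyl, or an amine at that same place would give a number like that of compound 4, or whether the lower number is particular to ethyl. They also leave open whether the same ethyl would lower the number on a core altered elsewhere, for instance with the carbonyl of the shared core replaced.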